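Swapping the ethyl on the aryl arm for methoxy

The compounds below may be only part of what the source reports. "The series", "measured", "known", "first", "only" and "open" are said of these compounds alone.

Of the compounds shown here, three with a shared core have been measured in an assay on isolated protein for inhibition of steroid 5-alpha-reductase (Rattus norvegicus); a lower number here means a stronger inhibitor, a higher number a weaker inhibitor. Compound 1 `COc1ccccc1N1CCN(CCCOc2ccc(C(=O)Nc3ccccc3OCCCC(=O)O)cc2)CC1`, which carries hydrogen on the saturated chain carbon bound to an aromatic oxygen, gives 41000 nM. Compound 2 `COc1ccccc1N1CCN(CCC(Oc2ccc(C(=O)Nc3ccccc3OCCCC(=O)O)cc2)c2cccc(C)c2)CC1` gives 360 nM, and compound 3 `CCc1ccc(C(CCN2CCN(c3ccccc3OC)CC2)Oc2ccc(C(=O)Nc3ccccc3OCCCC(=O)O)cc2)cc1` gives 70 nM, the lowest number of the three. The steps of a 110-fold lower number from compound 1 to compound 2 (2.06 log units; beyond the scatter) and a 590-fold lower number from compound 1 to compound 3 (2.77 log units; beyond the scatter) are large, and the step of a 5.1-fold lower number from compound 2 to compound 3 (0.71 log units; beyond the scatter) is modest. Compound 4 `COc1ccc(C(CCN2CCN(c3ccccc3OC)CC2)Oc2ccc(C(=O)Nc3ccccc3OCCCC(=O)O)cc2)cc1` differs from compound 3 by methoxy in place of ethyl on an aromatic carbon. Among the compounds with values here, no measured step exchanges ethyl for methoxy on that ring; only the modest step from compound 2 to compound 3 shows that the pattern on this ring moves the number at all. The change is therefore expected to produce a modest step, if any, and slightly in the weaker direction is the estimate, with a 2.1-fold higher number from compound 3 to compound 4 (0.33 log units; beyond the scatter). Compound 4 is estimated to give 150 nM in this assay, within a range from 40 nM to 500 nM.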

Compound 4, half-maximal inhibitory concentration: 170 nM
Estimate against measurement, compound 4: 1.1-fold (0.05 log units) below; the range from low to high includes it.
By their numbers in this assay, from the lowest: compound 3; then compound 4; then compound 2; then compound 1.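

In this assay methoxy in place of ethyl on this aromatic carbon moves the number beyond the scatter (a 2.4-fold higher number from compound 3 to compound 4 (0.39 log units; beyond the scatter)), so the group at this one carbon matters, not only the presence of an aryl arm. The 4-methoxyphenyl arm still keeps a large part of the gain over hydrogen (a 240-fold lower number from compound 1 to compound 4 (2.38 log units; beyond the scatter)) and also gives a lower number than the 3-methylphenyl arm (a 2.1-fold lower number from compound 2 to compound 4 (0.33 log units; beyond the scatter)), so both 4-substituted arms, in compound 3 and compound 4, lie below compound 2. The data shown offer no measurement that explains this change.

Going by these compounds, whether a hydroxyl, a chlorine or a propyl chain at this carbon would follow the same order remains open. A 4-methylphenyl arm would be needed to separate the effect of the group from that of its place on the ring.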